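The source may hold more compounds than are shown below. What is called first, only, known or untested is meant among the compounds shown, and "the series" means these compounds.

Compound 3 `CCCCNc1ccc(C(=O)O)cc1S(N)(=O)=O` gives 6.4% in an assay on HEK293 cells for inhibition of solute carrier family 12 member 2 (Homo sapiens), read by fluorescence, with a stated time of 30 min, tested at 100 uM (a higher number here means a stronger effect of the compound at the concentration tested, a lower number a weaker effect), the highest of the three numbers at hand, though not by a margin that means anything: the step of a number 1.7 percentage points higher from compound 1 to compound 3 (within the scatter) from compound 1 `CCCCNc1ccc([N+](=O)[O-])cc1S(N)(=O)=O`, which gives 4.7%, is within the scatter, and compound 2 `CCCCCCCCNc1ccc([N+](=O)[O-])cc1S(N)(=O)=O`, which gives 5.8%, sits close below compound 3. Compound 4 `CCCCCCCCNc1ccc(C(=O)O)cc1S(N)(=O)=O` is not yet measured. It differs from compound 3 by butyl in place of hydrogen on a saturated chain carbon, four bonds along the chain from a nitrogen on an aromatic ring. Going by the values given here, the one measured step that bears on this change is the same replacement made on the nitro-bearing core, a number 1.1 percentage points higher from compound 1 to compound 2 (within the scatter), which stayed within the scatter. Nothing in the measured compounds suggests that the carboxy-bearing core of compound 3 should respond differently, so no step beyond the scatter is expected. Compound 4 is therefore estimated at 7% in this assay, with a range from 0% to 16%, and the expected step of a number 0.6 percentage points higher from compound 3 to compound 4 (within the scatter) is one that would be indistinguishable from repeat measurement of compound 3 itself.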

Compound 4, a percentage reported as inhibition, at one concentration (the size of the read-out at that concentration, not a potency): 24%
Estimate against measurement, compound 4: 17 percentage points below; the measured number lies above the stated range.
By their numbers in this assay, from the lowest: compounds 1, 2 and 3 (each within the scatter of the next); then compound 4.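

On the carboxy-bearing core, butyl in place of hydrogen on a saturated chain carbon gives a number 17.6 percentage points higher from compound 3 to compound 4 (beyond the scatter) in this assay. Carboxy in place of nitro likewise gives a number 18.2 percentage points higher from compound 2 to compound 4 (beyond the scatter) once the longer chain is present. Neither change alone moves the read-out beyond the scatter, and among these compounds only the two together do, so their effects do not simply add: the same change on two cores in this assay, a number 1.7 percentage points higher (within the scatter) from compound 1 to compound 3 and a number 18.2 percentage points higher (beyond the scatter) from compound 2 to compound 4, 16.5 percentage points apart, beyond the scatter of two such steps

From the compounds shown here alone, whether a chain longer than that of compound 4 would raise the number further or lower it remains open, as does whether a tetrazole or an amide could take the place of carboxy. Compound 4 gives 24% at a single concentration, which leaves its potency undefined.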